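Rat clearance notes on a small amide series

A few compounds are considered here, and "the series" means these few. Any claim that something is new, unique, unknown or untested is made for them only; others in the source may bear on it.

Three compounds have been run in an ADME assay on the whole organism (Rattus norvegicus, strain Sprague-Dawley) for pharmacokinetics, using cassette dosing, at a dose of 0.5 mg/kg by the intravenous route; on this read-out lower numbers stand for slow clearance and higher numbers for fast clearance. Compound 1 `O=C(Nc1ccc2[nH]c(=O)oc2c1)C(=O)N1CCN(c2ccc(Cl)cc2)CC1` gives 7.2 mL/min/kg. Compound 2 `O=C(Nc1ccc2[nH]c(=O)oc2c1)C(=O)N1CCN(c2ccc(F)cc2)CC1` gives 11.1 mL/min/kg in this assay. Compound 3 `C[C@@H]1CN(C(=O)C(=O)Nc2ccc3[nH]c(=O)oc3c2)CCN1c1ccc(F)c(F)c1` gives 15.9 mL/min/kg in this assay; compound 3 differs from compound 2 in more than one place, and the difference between the two cores is not broken down here. Against compound 2 the number for compound 3 lies within the scatter, against compound 1 beyond it.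

One change is seen twice in the series. From compound 2 to compound 1 it is chloro in place of fluoro on an aromatic carbon, and it gave a 1.5-fold lower number from compound 2 to compound 1 (0.19 log units; within the scatter). Compound 4 `C[C@@H]1CN(C(=O)C(=O)Nc2ccc3[nH]c(=O)oc3c2)CCN1c1ccc(Cl)c(F)c1` is not yet measured; it arises from compound 3 by chloro in place of fluoro on an aromatic carbon. The two places are not the same: in compound 4 the site is ortho to a fluoro group, which the site in compound 1 is not, so this is the same kind of change rather than the same change. The step from compound 3 to compound 4 in this assay is expected to be a 1.3-fold lower number from compound 3 to compound 4 (0.12 log units; within the scatter), resting on the earlier step of a 1.5-fold lower number from compound 2 to compound 1 (0.19 log units; within the scatter), which stayed within the scatter. Compound 4 is estimated at 12 mL/min/kg, between 6 mL/min/kg and 25 mL/min/kg.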

Compound 4, clearance: 6 mL/min/kg
The estimate for compound 4 lay 2.0-fold (0.30 log units) above the measured number, within the range that was stated.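

In this assay, chloro in place of fluoro, here 3,4-difluorophenyl to 4-chloro-3-fluorophenyl, gave a 2.7-fold lower number from compound 3 to compound 4 (0.42 log units; beyond the scatter). Set beside the earlier step, the size of the change does not separate the two cores: the same change on two cores in this assay, a 1.5-fold lower number (0.19 log units; within the scatter) from compound 2 to compound 1 and a 2.7-fold lower number (0.42 log units; beyond the scatter) from compound 3 to compound 4, 1.7-fold (0.24 log units) apart, within the scatter of two such steps Carrying the change from one core to the other is therefore compatible with these data, but only this newer step lies beyond the scatter, two pairs set no rule for the series, and they do not show whether a site ortho to a fluoro group alters the step.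

Still open, going by these compounds, is whether other groups at the same aromatic carbon, such as methyl, methoxy, trifluoromethyl or a nitrile, would give a number close to that of chloro in this assay. Also open, on these data alone, is what an amine or a carboxylic acid at that carbon would do to clearance, and whether the chloro for fluoro step holds on further cores.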